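Adding a Chloro to a Compound Already at the Limit

The compounds below may be only part of what the source reports. "The series", "measured", "known", "first", "only" and "open" are said of these compounds alone.

Compound 1 `ClCc1ccc(Cn2cnc3c(Cl)ncnc32)cc1` and compound 2 `ClCc1cccc(Cn2cnc3ncnc(Cl)c32)c1` are built from the same pieces, arranged differently. In a functional assay on COLO 205 cells (Homo sapiens) for cytotoxicity, read by sulforhodamine B assay, with a stated time of 48 h (on this read-out lower numbers stand for stronger inhibition of growth and higher numbers for weaker inhibition of growth), compound 1 gives > 100000 nM, which is a limit of the assay rather than a number. In this assay compound 2 gives > 100000 nM, again a limit. Compound 2 therefore stands at the limit of > 100000 nM in this assay, at which 2 of the 2 values shown sit, with no numerical value to rank it against anything. Compound 3 `ClCc1cccc(Cn2cnc3nc(Cl)nc(Cl)c32)c1` has not yet been measured; it differs from compound 2 by chloro in place of hydrogen on an aromatic carbon. Among the measured compounds shown here, no step between two measured compounds has been recorded, so there is no measured change to draw on. The step of a number no higher from compound 2 to compound 3 (the limit leaves the size open) is expected to be none beyond the scatter, with a further limit the most likely outcome. Compound 3 is accordingly estimated at 100000 nM in this assay, within a range from 30000 nM to 100000 nM.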

Compound 3, concentration for total growth inhibition: 1650 nM
For compound 3 the middle estimate is 61-fold (1.78 log units) above the measured one; the whole stated range lies above it.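

Putting chloro in place of hydrogen on the aromatic carbon between two ring nitrogen atoms gives an at least 60-fold lower number from compound 2 to compound 3 (1.78 log units; beyond the scatter) in this assay. This position is therefore not silent: a change of a single heavy atom here is enough to move the compound off the limit, and the size of the step is only a minimum. Compound 3 is the only one of the three with a real number, while the others remain limits: the limit of > 100000 nM in this assay, at which 2 of the 3 values shown sit.

The compounds shown cannot tell whether chloro is special at this carbon or whether an amine or a methoxy group there would serve as well. Nor do they tell whether the same change on compound 1 would have a similar effect. They also give no information on how compound 3 inhibits growth.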